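The compounds below may be only part of what the source reports. "The series", "measured", "known", "first", "only" and "open" are said of these compounds alone.

Values in a functional assay on DU-145 cells (Homo sapiens) for inhibition, read by trypan blue exclusion, with a stated time of 96 h; a lower number here means a stronger inhibitor of growth, a higher number a weaker inhibitor of growth:
- compound 1 `O=C(/C(=C\c1ccc(OCc2ccccc2)cc1)SCc1ccc(Cl)cc1)c1ccc(Cl)cc1`: 1000 nM
- compound 2 `O=C(/C(=C\c1ccc(Br)cc1)SCc1ccc(Cl)cc1)c1ccc(Cl)cc1`: 1000 nM
- compound 3 `CCOc1ccc(/C=C(/Sc2ccccc2Cl)C(=O)c2ccc(Cl)cc2)cc1OC`: 50000 nM

Compound 1 stands level with compound 2, and together they hold the lowest number of the three, while compound 3 gives the highest. The change to compound 4 `O=C(/C(=C\c1ccc(OCc2ccccc2)cc1)S(=O)(=O)Cc1ccc(Cl)cc1)c1ccc(Cl)cc1` is (4-chlorobenzyl)sulfonyl in place of (4-chlorobenzyl)sulfanyl on a double-bonded chain carbon bound to a carbonyl carbon and a double-bonded chain carbon, on a double-bonded chain carbon bound to a carbonyl carbon and a double-bonded chain carbon.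

Going by the values given here, no measured compound carries the sulfonyl group, so no measured step tests this change directly. Among the compounds with values here, the one single-place step, no change at the digits printed from compound 1 to compound 2 (within the scatter), lies elsewhere on the molecule and stayed within the scatter. Compound 3 differs from compound 1 in more than one place and does not isolate the change. The expectation therefore starts from compound 1 at 1000 nM in this assay and allows a modest move towards a higher number, with wide uncertainty in either direction. The expected step is a 2.0-fold higher number from compound 1 to compound 4 (0.30 log units; within the scatter). For compound 4 the estimated value is 2000 nM, with an expected range of 300 nM to 15000 nM.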

Compound 4, concentration for 50% growth inhibition: 1000 nM
For compound 4 the middle estimate is 2.0-fold (0.30 log units) above the measured one; the measured number falls inside the stated range.
By their numbers in this assay, from the lowest: compounds 1, 2 and 4 (each within the scatter of the next); then compound 3.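

In this assay, going by these compounds alone, the sulfur link at this position was tested directly for the first time: (4-chlorobenzyl)sulfonyl in place of (4-chlorobenzyl)sulfanyl gives no change at the digits printed from compound 1 to compound 4 (within the scatter). Within the data shown here, the earlier single-place step lay elsewhere on the molecule, so this is the first sign that the double-bonded chain carbon bound to a carbonyl carbon and a double-bonded chain carbon tolerates this change, at least with the benzyloxy group of compound 1 in place. No supporting data bear on why the number holds across this change.

As far as these compounds go, whether the same holds with the bromo group of compound 2 remains open. So does the outcome at this position for (4-chlorobenzyl)sulfinyl, or for a group of another kind such as an amine or a carboxylic acid.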